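Series notes: azole swap on the piperidine nitrogen

The source may report more compounds than this note shows. Statements on the series, on what has been measured and on what is new or still open speak of the compounds shown alone.

Measured so far in a functional assay on CHO-K1 cells for agonist activity at Glucose-dependent insulinotropic receptor (Mus musculus), read by HTRF and cAMP accumulation, with a stated time of 30 min; a higher number here means a larger maximal response, a lower number a smaller maximal response:
- compound 1 `COc1cnc(N2CCC(CCCNc3ccc4c(c3)OCC4=O)CC2)nc1`: 106%
- compound 2 `COC(=O)c1cnc(N2CCC(CCCNc3ccc4c(c3)OCC4=O)CC2)nc1`: 67%
- compound 3 `CC(C)c1nc(N2CCC(CCCNc3ccc4c(c3)OCC4=O)CC2)no1`: "not determined" (no result reported) in this assay

Compound 3 stands without a number; nothing can be said of where it sits relative to compound 1 or compound 2. Compound 4 `CC(C)c1nsc(N2CCC(CCCNc3ccc4c(c3)OCC4=O)CC2)n1` differs from compound 3 only in that (3-isopropyl-1,2,4-thiadiazol-5-yl in place of 5-isopropyl-1,2,4-oxadiazol-3-yl on an amine nitrogen in a ring). Going by the values given here, no measured step covers this change. Among the compounds with values here, the single step in hand, a number 39 percentage points lower from compound 1 to compound 2 (beyond the scatter), concerns a different position and a different kind of group, so it gives no direction for the present swap; it shows only that a single substituent change can move the maximal response well beyond the scatter. With no anchor value for compound 3, the estimate for compound 4 is wide. Compound 4 is expected to reach roughly 85%, with a plausible range from 40% to 115%.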

Compound 4, largest response reached (Emax), in percent of the reference or control that the assay uses: 93%
For compound 4 the middle estimate is 8 percentage points below the measured one; the measured number falls inside the stated range.
By their numbers in this assay, from the lowest: compound 2; then compound 4; then compound 1.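

In this assay a five-membered aromatic ring, as the 3-isopropyl-1,2,4-thiadiazol-5-yl of compound 4, is tolerated on the amine nitrogen in a ring and gives 93% as maximal response. The response shows a number 26 percentage points higher from compound 2 to compound 4 (beyond the scatter) and a number 13 percentage points lower from compound 1 to compound 4 (beyond the scatter), so this group does not match the 5-methoxypyrimidin-2-yl, but exceeds the 5-(methoxycarbonyl)pyrimidin-2-yl. Nothing in hand gives a reason for these steps.

The swap from compound 3 to compound 4 cannot be read. Also open, as far as these compounds go, is how a cyclopropyl or a tert-butyl group in place of the isopropyl would change the response.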